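The source may hold more compounds than are shown below. What is called first, only, known or untested is meant among the compounds shown, and "the series" means these compounds.

Working notes on the series

Compound 1 `Cc1cc(C)cc(S(=O)(=O)c2c(C(=O)NCc3cccc(N)c3)[nH]c3ccc(Cl)cc23)c1` and compound 2 `Cc1cc(C)cc(S(=O)(=O)c2c(C(=O)NCC(=O)NCCn3c(C)cnc3[N+](=O)[O-])[nH]c3ccc(Cl)cc23)c1` share the same core and differ in the chain carried by the amide nitrogen. In an ADME assay on MT4 cells (Homo sapiens) for cytotoxicity, read by MTT assay (a higher number here means that more compound is tolerated, a lower number that less compound is tolerated), compound 1 gives only a limit, > 53400 nM, and not a number. In this assay, for the measured compounds named here, compound 2 gives 24500 nM, which is the only number in the set so far. The other entry is the limit at which compound 1 sits, (the limit of > 53400 nM in this assay, at which 1 of the 2 values shown sits). Going by the values given here, compound 2 therefore stands alone as the single measured point, with no measured step to compare it against.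

Compound 3 `Cc1cc(C)cc(S(=O)(=O)c2c(C(=O)NCC(=O)NCc3ccncn3)[nH]c3ccc(Cl)cc23)c1` follows from compound 2 by one change: a group of 6 heavy atoms (4 carbon, 2 nitrogen; one six-membered aromatic ring with 2 hetero atoms) in place of a group of 10 heavy atoms (5 carbon, 3 nitrogen, 2 oxygen; one five-membered aromatic ring with 2 hetero atoms), on a saturated chain carbon bound to an amide-type nitrogen. Among the compounds with values here, no measured pair isolates this kind of exchange, so no size of step is established from the data. The expectation for the step from compound 2 to compound 3 in this assay is a modest rise in the tolerated concentration, a 1.6-fold higher number from compound 2 to compound 3 (0.21 log units; within the scatter), small enough that it may still sit near the scatter. Compound 3 is accordingly estimated at 40000 nM, with a range from 15000 nM to 110000 nM, and a fair chance that only a limit is returned.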

Compound 3, half-maximal cytotoxic concentration: > 48800 nM
Compound 3 gave a limit, no number (the forecaster's own chance of this, stated with the estimate: 35%); middle value at least 1.2-fold (0.08 log units) away from the limit.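

For the compounds shown here, on the saturated chain carbon bound to an amide-type nitrogen, in this assay, pyrimidin-4-yl in place of the group of 10 heavy atoms with its five-membered aromatic ring gives an at least 1.9-fold higher number from compound 2 to compound 3 (0.29 log units; that floor lies within the scatter), the first single exchange that can be read at all, although only as a floor. From the compounds shown here alone, compound 3 gives a limit and not a number: the limit of > 48800 nM in this assay, at which 1 of the 3 values shown sits. The true size of the step therefore remains unknown, and since the floor lies within the scatter, the pair does not establish a change beyond the scatter, although the exchange removes no measured tolerance from compound 2 to compound 3.

The step between compound 1 and compound 3 cannot be read, as both entries are limits, so these two compounds cannot be ordered in this assay. Going by these compounds, it remains open whether the ring itself or the length of the chain governs the outcome at this position, a question that a simple amine or a carboxylic acid on the same chain carbon, or a longer chain carrying pyrimidin-4-yl, would bear on.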